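Removing One Phenyl Ring From Three Weak Inhibitors

A few compounds are considered here, and "the series" means these few. Any claim that something is new, unique, unknown or untested is made for them only; others in the source may bear on it.

compound 1 `N#Cc1ccnc(OC(=O)N2CCC(C(c3ccccc3)c3ccccc3)CC2)c1`: > 1000 nM
compound 2 `N#Cc1cccc(OC(=O)N2CCC(C(c3ccccc3)c3ccccc3)CC2)c1`: > 1000 nM
compound 3 `N#Cc1cccc(OC(=O)N2CCC(C(c3ccccc3)c3ccccc3)CC2)n1`: > 1000 nM

Three compounds share one core and differ only in the aromatic ring on the oxygen next to a carbonyl group. In an assay on isolated protein for inhibition of Fatty-acid amide hydrolase 1 (Rattus norvegicus), read by fluorescence (on this read-out lower numbers stand for stronger inhibition and higher numbers for weaker inhibition), compound 1 gives > 1000 nM, which is a limit of the assay rather than a number. Compound 2 gives > 1000 nM, also a limit. Compound 3 gives > 1000 nM, again a limit. Because all three sit at the limit of > 1000 nM in this assay, at which 3 of the 3 values shown sit, the steps a step that the two limits leave unreadable from compound 1 to compound 2, a step that the two limits leave unreadable from compound 1 to compound 3 and a step that the two limits leave unreadable from compound 2 to compound 3 cannot be read in size or direction.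

Compound 4 `N#Cc1cccc(OC(=O)N2CCC(Cc3ccccc3)CC2)c1` has not yet been measured. It differs from compound 2 by hydrogen in place of phenyl on a saturated chain carbon bound to an aromatic carbon and a saturated ring carbon. Among the measured compounds shown here, none of the measured steps changes this part of the molecule, and all of them are unreadable, so no measured step sets a size or direction for the change in this assay. The step that the limit leaves unreadable from compound 2 to compound 4 is therefore estimated to stay small. Compound 4 is expected at about 3000 nM, most likely reported again as a limit, within a range from 500 nM to 30000 nM.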

Compound 4, half-maximal inhibitory concentration: 44.7 nM
Compound 4: middle estimate off by 67-fold (1.83 log units), on the high side, and the stated range ends above it.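

In this assay putting hydrogen in place of phenyl on a saturated chain carbon bound to an aromatic carbon and a saturated ring carbon gives an at least 22-fold lower number from compound 2 to compound 4 (1.34 log units; beyond the scatter) and so marks this carbon as a place where one change moves the read-out well beyond the scatter. Among the compounds shown here, the steps among compound 1, compound 2 and compound 3 cannot be read, which makes this the first readable change. Compound 4 is the only compound shown with a number instead of a limit: the limit of > 1000 nM in this assay, at which 3 of the 4 values shown sit.

On these data alone, whether the 4-cyanopyridin-2-yl and 6-cyanopyridin-2-yl rings would differ from 3-cyanophenyl on the core of compound 4 stays open. Also open, as far as these compounds go, is how a methyl group or an amine would compare with hydrogen on this carbon.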